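From 4-fluorophenyl to 3-chlorophenyl on the shared core

The source may hold more compounds than are shown below. What is called first, only, known or untested is meant among the compounds shown, and "the series" means these compounds.

Compound 1 `COc1ccc(-c2nc(N)c(Oc3ccccc3OC)c(Cl)n2)cc1`: 8200 nM
Compound 2 `COc1ccccc1Oc1c(N)nc(-c2ccc(F)cc2)nc1Cl`: 42600 nM

In a toxicity assay on HaCaT cells (Homo sapiens) for cytotoxicity, read by CCK-8 assay, with a stated time of 24 h (a lower number here means that less compound is tolerated, a higher number that more compound is tolerated), compound 2 gives the higher of the two measured numbers, 42600 nM. Compound 3 `COc1ccccc1Oc1c(N)nc(-c2cccc(Cl)c2)nc1Cl` differs from compound 2 in one place: 3-chlorophenyl in place of 4-fluorophenyl on an aromatic carbon. Within the data shown here, only one measured step bears on this change, fluoro in place of methoxy on an aromatic carbon, which gave a 5.2-fold higher number from compound 1 to compound 2 (0.72 log units; beyond the scatter). That modest step lies beyond the scatter, so a change of this kind can move the number in this assay. Among the measured compounds shown here, no measured compound carries the 3-chlorophenyl group, which leaves the expectation loose. With compound 2 at 42600 nM, the higher end of this small set, a moderate move to a lower number seems most likely. The expected change is a 1.9-fold lower number from compound 2 to compound 3 (0.29 log units; within the scatter). For compound 3 the estimated value is 22000 nM, with an expected range from 8000 nM to 60000 nM.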

Compound 3, half-maximal cytotoxic concentration: > 80000 nM
Compound 3 was reported as a limit; the forecaster's own chance of this, stated with the estimate: 15%; middle value at least 3.6-fold (0.56 log units) from the limit.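

In this assay, compound 3 stands at a limit of the assay, not at a number: the limit of > 80000 nM in this assay, at which 1 of the 3 values shown sits. Placing 3-chlorophenyl in place of 4-fluorophenyl gives an at least 1.8-fold higher number from compound 2 to compound 3 (0.27 log units; that floor lies within the scatter), so this change shows no move to a lower number, although the floor of the step does not separate the two groups. Set against the 4-methoxyphenyl group, the same 3-chlorophenyl group gives an at least 9.7-fold higher number from compound 1 to compound 3 (0.98 log units; beyond the scatter), which leaves compound 1 the lowest of the three at this position, with both halogen-bearing groups on the higher side.

From the compounds shown here alone, how far compound 3 lies past its limit remains open, and with it the true size of the change from 4-fluorophenyl. Also open, going by these compounds, is whether the chlorine or its placement matters, which 4-chlorophenyl or 3-fluorophenyl could address, and how a phenyl bearing an amine or a carboxylic acid would read here.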